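From a dimethylcarbamoyl side chain to propoxy

A few compounds are considered here, and "the series" means these few. Any claim that something is new, unique, unknown or untested is made for them only; others in the source may bear on it.

Three compounds sharing one core have been taken into a physicochemical assay for lipophilicity, using the shake flask method, in phosphate buffer, measured as octanol-water partition, with a stated time of 24 h, at pH 7.4, tested at 100 uM (on this read-out lower numbers stand for lower lipophilicity and higher numbers for higher lipophilicity), so far. Compound 1 (`Cc1cc(OC(C)C)cc(C)c1-c1cccc(COc2ccc(OCC(=O)O)c(F)c2)c1`) is entered as "not determined" (no result reported) and offers no number. Among the compounds with values here, compound 2 (`CCOc1cc(C)c(-c2cccc(COc3ccc(OCC(=O)O)c(F)c3)c2)c(C)c1`) gives 3.48 in that test, the only number available. Like compound 1, compound 3 (`Cc1cc(OCC(=O)N(C)C)cc(C)c1-c1cccc(COc2ccc(OCC(=O)O)c(F)c2)c1`) is entered as "not determined" (no result reported) and has no single number of its own, so its standing in this assay cannot be ranked against compound 2.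

Compound 4 (`CCCOc1cc(C)c(-c2cccc(COc3ccc(OCC(=O)O)c(F)c3)c2)c(C)c1`) has yet to be measured. The change that leads to it is ethyl in place of dimethylcarbamoyl on a saturated chain carbon bound to an oxygen on an aromatic ring, which can equally be read as (dimethylcarbamoyl)methoxy to propoxy. Within the data shown here, no measured pair in the set shows a step of this kind. A clear upward step in this assay beyond the usual scatter is nevertheless expected for this change, although its size cannot be fixed without a number for the starting compound. Among the measured compounds shown here, the only anchor is compound 2 at 3.48 and the reading expected here lies somewhat higher than that. The estimate for compound 4 is an expected 3.9 ( range 3.5 to 4.3).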

Compound 4, distribution coefficient: 3.64
Beside the measured number, compound 4's estimate is 0.26 log units above it; the range from low to high includes it.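

Within the data shown here, the result gives the first measured step on this side chain in this assay: a number 0.16 log units higher from compound 2 to compound 4 (within the scatter), for methyl in place of hydrogen on a saturated chain carbon, two bonds along the chain from an oxygen on an aromatic ring. Ethoxy and propoxy at this position therefore cannot be told apart on this read-out, and one added chain carbon here makes no difference that stands clear of repeat measurements. The change from dimethylcarbamoyl to ethyl itself still cannot be read, as compound 3 offers no number to start from, and nothing at hand bears on what lies behind either reading.

What the compounds shown leave open is how far the chain can be extended before the reading parts from those of compound 2 and compound 4, for instance with a butoxy or a longer chain on the same oxygen. They also leave open how a terminal amine or a carboxylic acid at the end of this chain would stand in this assay against these two ethers.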